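Diethylamino for Dimethylamino: Expected Cytotoxicity of Compound 4

This account rests on a few compounds, and the source may have more. Where it says the series, first, only, none or still open, it means among the compounds named here.

Measured in an ADME assay on HEK293 cells (Homo sapiens) for cytotoxicity, read by MTT assay, with a stated time of 48 h; a higher number here means a weaker inhibitor, a lower number a stronger inhibitor:
compound 1, `CN(C)CCn1c(N)c(-c2nc3ccccc3[nH]2)c2nc(C#N)c(C#N)nc21`, gives 9730 nM
compound 2, `CCN(CC)CCn1c(N)c(-c2nc3ccccc3[nH]2)c2nc(C#N)c(C#N)nc21`, gives 12200 nM
compound 3, `CN(C)CCCCn1c(N)c(-c2nc3cc(Cl)ccc3[nH]2)c2nc(C#N)c(C#N)nc21`, gives 4730 nM

Compound 2 differs from compound 1 by one change, (diethylamino in place of dimethylamino on a saturated chain carbon, two bonds along the chain from an aromatic nitrogen), and this change produced a 1.3-fold higher number from compound 1 to compound 2 (0.10 log units; within the scatter) in this assay. Compound 3 carries a different core; the difference between the core of compound 3 and the core of compound 1 is not broken down here. In this assay compound 3 gives the lowest of the three numbers, and its distance to both compound 1 and compound 2 lies beyond the scatter.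

Compound 4, `CCN(CC)CCCCn1c(N)c(-c2nc3cc(Cl)ccc3[nH]2)c2nc(C#N)c(C#N)nc21`, has not been measured. It differs from compound 3 by diethylamino in place of dimethylamino on a saturated chain carbon, four bonds along the chain from an aromatic nitrogen. This is the same kind of change as that from compound 1 to compound 2, but the place is not identical: there the amine sits two bonds along the chain from the aromatic nitrogen, here four bonds along the chain from the aromatic nitrogen. Because the earlier step of a 1.3-fold higher number from compound 1 to compound 2 (0.10 log units; within the scatter) lay within the scatter, the step from compound 3 to compound 4 is expected to be small as well, a 1.2-fold higher number from compound 3 to compound 4 (0.07 log units; within the scatter). Compound 4 is therefore estimated at 5500 nM in this assay, with a likely range from 2800 nM to 11000 nM.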

Compound 4, half-maximal inhibitory concentration: 3860 nM
For compound 4 the middle estimate is 1.4-fold (0.15 log units) above the measured one; low and high end bracket the measured number.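

In this assay, replacing dimethylamino with diethylamino on the core of compound 3 gave a 1.2-fold lower number from compound 3 to compound 4 (0.09 log units; within the scatter). Set beside the earlier step, this shows that the change could be carried from one core to the other in this series without a measurable difference in its effect: the same change on two cores in this assay, a 1.3-fold higher number (0.10 log units; within the scatter) from compound 1 to compound 2 and a 1.2-fold lower number (0.09 log units; within the scatter) from compound 3 to compound 4, 1.5-fold (0.19 log units) apart, within the scatter of two such steps. For the compounds shown here, with only two pairs, each step within the scatter, it does not show that the change has a set size or direction on any further core, and the two pairs also differ in how far along the chain the amine sits.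

The compounds shown leave open whether the same holds for a larger amine such as dipropylamino, for a cyclic amine, or for a primary amine at the end of the chain. They also leave open how the change behaves on a 3-(dimethylamino)propyl chain, and whether a step beyond the scatter appears with any of these groups.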